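This account rests on a few compounds, and the source may have more. Where it says the series, first, only, none or still open, it means among the compounds named here.

Among the measured compounds shown here, compound 1 `COc1cc(-c2cc(/C=C/C(=O)c3ccc(N)cc3)[nH]n2)cc(OC)c1OC` is the stronger of the two compounds measured so far in a functional assay on ACHN cells (Homo sapiens) for cytotoxicity, read by sulforhodamine B assay, with a stated time of 48 h, tested at 10 uM (on this read-out higher numbers stand for a weaker effect at the one concentration tested and lower numbers for a stronger effect), where compound 1 gives -61%. Its partner, compound 2 `COc1cc(-c2cc(/C=C/C(=O)c3ccc(Cl)c(Cl)c3)[nH]n2)cc(OC)c1OC`, gives 67% in this assay. The shift a number 128 percentage points higher from compound 1 to compound 2 (beyond the scatter) goes with a change on the carbonyl side of the shared core. Compound 3 `COc1ccc(-c2cc(/C=C/C(=O)c3ccc(N)cc3)[nH]n2)cc1OC` differs from compound 1 on the other side of the core: hydrogen in place of methoxy on an aromatic carbon. No measured step touches this part of the molecule, so the only shown step does not bear on the change from compound 1 to compound 3, and the expectation can rest only on the change itself. A modest weakening of the effect is expected for compound 3, roughly a number 41 percentage points higher from compound 1 to compound 3 (beyond the scatter), with the chance of none beyond the scatter. Compound 3 is therefore estimated at -20% in this assay, within a range of -70% to 50%.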

Compound 3, a percentage reported as activity, at one concentration (the size of the read-out at that concentration, not a potency): -82%
Compound 3: the middle estimate sits 62 percentage points above what was measured, outside the stated range (below it).
By their numbers in this assay, from the lowest: compound 3; then compound 1; then compound 2.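

In this assay, among the compounds shown here, the read-out gives a number 21 percentage points lower from compound 1 to compound 3 (beyond the scatter) as the first measured change on this side of the shared core, with hydrogen in place of methoxy on an aromatic carbon. For this pair, the methoxy group at this place, ortho to a methoxy group and meta to a large group, is therefore not required for the effect, which is stronger with hydrogen there. Nothing at hand explains this shift.

The compounds shown leave open whether a hydroxyl group, a fluorine atom or an amine at this place would act like hydrogen, and whether replacing the remaining methoxy groups would shift the read-out further. They also leave open whether the same change would give a similar step with 3,4-dichlorophenyl on the carbonyl carbon, as in compound 2.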